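This account rests on a few compounds, and the source may have more. Where it says the series, first, only, none or still open, it means among the compounds named here.

Measured in a functional assay on A549 cells (Homo sapiens) for cytotoxicity, read by MTT assay, with a stated time of 72 h; on this read-out higher numbers stand for weaker inhibition and lower numbers for stronger inhibition:
Compound 1 `CNC(=O)c1cc(Oc2ccc(C(=O)/C=C/c3ccco3)cc2)ccn1`: "not determined" (no result reported)
Compound 2 `CNC(=O)c1cc(Oc2ccc(C(=O)/C=C/c3ccc(Br)cc3)cc2)ccn1`: > 50000 nM
Compound 3 `CNC(=O)c1cc(Oc2ccc(C(=O)/C=C/c3ccc([N+](=O)[O-])cc3)cc2)ccn1`: > 50000 nM

Compound 3 gives no number, only a limit: > 50000 nM. Compound 2 also gives only a limit: > 50000 nM. The evidence therefore comes down to the limit of > 50000 nM in this assay, at which 2 of the 3 values shown sit, and compound 1 adds no result to it.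

Compound 4 `CNC(=O)c1cc(Oc2ccc(C(=O)/C=C/c3ccc(C#N)cc3)cc2)ccn1` has not yet been measured. Its structure departs from that of compound 3 in one place, on an aromatic carbon of a six-membered aromatic ring of carbon only, para to a large group: cyano in place of nitro on an aromatic carbon. In words, this is cyano in place of nitro.

Going by the values given here, only one measured step bears on this change, the swap at the same place, and it is a step that the two limits leave unreadable from compound 2 to compound 3. It offers no size or direction to carry over, so no real shift is expected in this assay. The expected change is a number no higher from compound 3 to compound 4 (the limit leaves the size open). For compound 4 the estimated value is 50000 nM, with an expected range from 20000 nM to 100000 nM, and a report of only a limit is the likeliest outcome.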

Compound 4, half-maximal inhibitory concentration: 26400 nM
Compound 4: the middle estimate sits 1.9-fold (0.28 log units) above what was measured; the range from low to high includes it.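

In this assay compound 4, which carries the 4-cyanophenyl group, gives 26400 nM as the first actual number at this position among the compounds shown. Cyano in place of nitro gives an at least 1.8-fold lower number from compound 3 to compound 4 (0.27 log units; that floor lies within the scatter) and cyano in place of bromo gives an at least 1.8-fold lower number from compound 2 to compound 4 (0.27 log units; that floor lies within the scatter) so both changes now have a printed direction, though neither floor clears the usual scatter. The step between the two compounds that stop at a limit still cannot be read, and the remaining weight of the series rests on that limit: the limit of > 50000 nM in this assay, at which 2 of the 4 values shown sit.

The compounds shown leave open how large either step really is, since each is measured against a limit and not a number. They also leave open whether an amine, a carboxylic acid or a methoxy group on this aromatic carbon would give a number in this assay at all.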